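Removing the Dimethylamino Group from a Phenylamide Series

The source may report more compounds than this note shows. Statements on the series, on what has been measured and on what is new or still open speak of the compounds shown alone.

Three compounds sharing one core were measured in an assay on isolated protein for inhibition of Ectonucleotide pyrophosphatase/phosphodiesterase family member 1 (Homo sapiens), tested at 10 uM; on this read-out lower numbers stand for less inhibition and higher numbers for more inhibition at the one concentration tested (going by the name of the read-out). Compound 1 `Cc1ccc(NC(=O)CSc2nc3cccnc3[nH]2)cc1C` gives 11%, compound 2 `COc1ccc(NC(=O)CSc2nc3ccc(OCC(F)(F)F)nc3[nH]2)cc1OC` gives 61%, and compound 3 `CN(C)c1ccc(NC(=O)CSc2nc3cccnc3[nH]2)cc1` gives 23%. Compound 3 thus holds the second highest of the three numbers: compound 1 lies below it by a gap beyond the scatter, and compound 2 lies above it by a larger gap, also beyond the scatter. Compound 4 `O=C(CSc1nc2cccnc2[nH]1)Nc1ccccc1` is not yet measured; it differs from compound 3 in one place: hydrogen in place of dimethylamino on an aromatic carbon. Among the compounds with values here, no step of this kind has been measured among the three compounds. In this assay a small downward step is expected, estimated as a number 10 percentage points lower from compound 3 to compound 4 (within the scatter). Compound 4 is therefore expected to give about 13%, between 2% and 30%.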

Compound 4, a percentage reported as inhibition, at one concentration (the size of the read-out at that concentration, not a potency): 30%
Compound 4: middle estimate off by 17 percentage points, on the low side; the measured number falls inside the stated range.
By their numbers in this assay, from the lowest: compound 1; then compounds 3 and 4 (each within the scatter of the next); then compound 2.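

In this assay, the exchange of dimethylamino for hydrogen on an aromatic carbon para to a large group amounts to a number 7 percentage points higher from compound 3 to compound 4 (within the scatter), the first one-place step read in this series. At this position, dimethylamino can therefore be lost with no change beyond the scatter, and the unsubstituted compound 4 serves as a reference for the position. Nothing available explains this outcome. As far as these compounds go, it remains open whether a carboxylic acid or a primary amine at this position would move the number beyond the scatter. From the compounds shown here alone, the same exchange on the core of compound 2 also remains open.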